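Swapping the anilino substituent in a weakly cytotoxic series

The source may hold more compounds than are shown below. What is called first, only, known or untested is meant among the compounds shown, and "the series" means these compounds.

Compound 1 `Fc1cccc(-c2nc(Nc3ccccc3)c3cc(F)ccc3n2)c1`: 47800 nM
Compound 2 `COc1ccccc1Nc1nc(-c2cccc(F)c2)nc2ccc(F)cc12`: a limit, > 50000 nM

In a functional assay on MDA-MB-231 cells (Homo sapiens) for cytotoxicity, read by MTT assay, with a stated time of 48 h (on this read-out higher numbers stand for weaker inhibition and lower numbers for stronger inhibition), compound 1 gives 47800 nM. For compound 2 this assay reports only a limit, > 50000 nM, so compound 2 stands at the weak end of what can be measured here (the limit of > 50000 nM in this assay, at which 1 of the 2 values shown sits). Among the measured compounds shown here, the one measured step, methoxy in place of hydrogen on an aromatic carbon, reads an at least 1.0-fold higher number from compound 1 to compound 2 (0.01 log units; that floor lies within the scatter).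

Compound 3 `Cc1ccc(Nc2nc(-c3cccc(F)c3)nc3ccc(F)cc23)cc1` differs from compound 2 in one place: 4-methylphenyl in place of 2-methoxyphenyl on a nitrogen on an aromatic ring. For the measured compounds named here, the only measured step concerns a different substituent on that same ring and stayed within the scatter, so it gives no reason to expect movement in either direction. Compound 3 is therefore expected to stay close to compound 2, with an expected step of a number no higher from compound 2 to compound 3 (the limit leaves the size open). The estimate for compound 3 is 50000 nM, within 20000 nM to 120000 nM.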

Compound 3, half-maximal inhibitory concentration: > 50000 nM
Compound 3: no number, only a limit; the forecaster's own chance of this, stated with the estimate: 55%; the middle value lies on the limit itself.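

With 4-methylphenyl in place of 2-methoxyphenyl on the nitrogen, this assay again gives only a limit: for compound 3 it is > 50000 nM. The step between the two limits cannot be read, so the two groups cannot be ranked against each other. Methyl in place of hydrogen gives an at least 1.0-fold higher number from compound 1 to compound 3 (0.01 log units; that floor lies within the scatter), so like methoxy it shows no stronger inhibition than the plain anilino compound, and the series now gathers at the weak end of the read-out: the limit of > 50000 nM in this assay, at which 2 of the 3 values shown sit.

Going by these compounds, whether any change on this ring can bring the number down remains open. An amine or a carboxylic acid on the ring, or a longer chain in place of the methyl, would show whether this position can give measurable cytotoxicity.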